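Ring methyl on sulfamoyl anilides: all at the limit

The compounds below may be only part of what the source reports. "The series", "measured", "known", "first", "only" and "open" are said of these compounds alone.

Compound 1, `CCN1CCCC1CNC(=O)c1cc(NS(=O)(=O)NC)ccc1OC`, gives in a functional assay on the whole organism for inhibition, with Mus musculus as the target (on this read-out higher numbers stand for an effect only at larger amounts of compound and lower numbers for an effect already at smaller amounts), only a limit, > 50 mg/kg.
Compound 2, `CCN1CCCC1CNC(=O)c1cc(NS(=O)(=O)NC)c(C)cc1OC`, gives only a limit, > 50 mg/kg.
Compound 3, `CCN1CCCC1CNC(=O)c1cc(NS(N)(=O)=O)ccc1OC`, gives only a limit, > 50 mg/kg.

None of the three measured compounds reaches a readable number; all sit at the limit of > 50 mg/kg in this assay, at which 3 of the 3 values shown sit. Compound 2 arises from compound 1 by methyl in place of hydrogen on an aromatic carbon, and the step that the two limits leave unreadable from compound 1 to compound 2 stays hidden behind the two limits. Compound 3 arises from compound 1 by hydrogen in place of methyl on a sulfonamide nitrogen, and the step that the two limits leave unreadable from compound 1 to compound 3 is hidden in the same way. Compound 4, `CCN1CCCC1CNC(=O)c1cc(NS(N)(=O)=O)c(C)cc1OC`, is not yet measured; it differs from compound 3 by methyl in place of hydrogen on an aromatic carbon. This is the same kind of change as that from compound 1 to compound 2, though the surroundings differ: here the methyl sits ortho to a sulfamoylamino group, there ortho to a (methylsulfamoyl)amino group. With every neighbour stuck at the limit, the best expectation is that compound 4 also returns only a limit, so compound 4 is estimated at 100 mg/kg. That estimate means an expected step that the limit leaves unreadable from compound 3 to compound 4, resting on nothing firmer than the unreadable step that the two limits leave unreadable from compound 1 to compound 2.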

Compound 4, dose for half-maximal effect: > 50 mg/kg
Compound 4: a limit, no number; the forecaster's own chance of this, stated with the estimate: 85%; the middle value lies beyond the limit too.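

Compound 4 also gives only a limit, so neither the step to it from compound 3 nor the step to it from compound 2 can be read, and all four compounds share one limit: the limit of > 50 mg/kg in this assay, at which 4 of the 4 values shown sit.

The compounds shown leave open whether either methyl, on the aromatic carbon or on the sulfonamide nitrogen, changes the dose for half-maximal effect at all.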